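From Isopropyl to Phenoxymethyl on a Shared Core

A few compounds are considered here, and "the series" means these few. Any claim that something is new, unique, unknown or untested is made for them only; others in the source may bear on it.

Of the compounds shown here, two built on one core have been measured in an assay for inhibition of Amine oxidase [flavin-containing] A (Homo sapiens), read by fluorescence and spectrophotometry, using microsomes, with stated times of 30 min and 20 min; on this read-out higher numbers stand for weaker inhibition and lower numbers for stronger inhibition. Compound 1 `Cc1ccc(-c2nc(-c3ccc(C4=NCCN4)cc3)no2)cc1` gives 2310 nM, and compound 2 `CC(C)c1noc(-c2ccc(C3=NCCN3)cc2)n1` gives 22500 nM. Among the measured compounds shown here, compound 2 thus stands at the highest of the two numbers, and its only neighbour, compound 1, sits at a markedly lower number, a gap beyond the scatter. Compound 3 `c1ccc(OCc2noc(-c3ccc(C4=NCCN4)cc3)n2)cc1` has not yet been measured in this assay. It differs from compound 2 in one place: phenoxymethyl in place of isopropyl on an aromatic carbon, on an aromatic carbon of a five-membered aromatic ring with two nitrogen and one oxygen. For the measured compounds named here, no step between measured compounds covers this exchange, so the expectation rests on the two numbers alone. Because compound 1 gives 2310 nM and compound 2 gives 22500 nM, and compound 3 brings a six-membered aromatic ring where compound 2 has isopropyl, a move to a lower number beyond the scatter is expected. The expected step is a 4.5-fold lower number from compound 2 to compound 3 (0.65 log units; beyond the scatter). Compound 3 is estimated at 5000 nM, in a range from 1500 nM to 16000 nM.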

Compound 3, half-maximal inhibitory concentration: > 100000 nM
Compound 3 was reported as a limit (the forecaster's own chance of this, stated with the estimate: 5%); at least 20-fold (1.30 log units) between middle value and limit.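

In this assay, compound 3 is reported only as a limit, not as a number: the limit of > 100000 nM in this assay, at which 1 of the 3 values shown sits.

Phenoxymethyl in place of isopropyl on an aromatic carbon gives an at least 4.4-fold higher number from compound 2 to compound 3 (0.64 log units; beyond the scatter), the first step that can be read at this position of the shared core. It shows that a six-membered aromatic ring, when it enters as phenoxymethyl at this position, does not go with stronger inhibition, and that the change is beyond the usual scatter.

The compounds shown do not separate the ring of phenoxymethyl from its oxygen, so they leave open which part goes with the step. They also leave open how a phenyl group attached directly, a smaller alkyl group such as methyl, an amine or a carboxylic acid would read at this position.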